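Swapping Fluoro for Methyl on Compound 2

The compounds below may be only part of what the source reports. "The series", "measured", "known", "first", "only" and "open" are said of these compounds alone.

In a functional assay on CCRF-CEM cells (Homo sapiens) for inhibition (on this read-out lower numbers stand for stronger inhibition and higher numbers for weaker inhibition), compound 1 `O=C1/C(=C/c2ccc(Br)cc2)Cc2ccccc21` gives 284000 nM and compound 2 `O=C1CCCCC/C1=C\c1ccc(F)cc1` gives 198000 nM and these two numbers lie within the usual scatter of each other. Compound 3 `Cc1ccc(/C=C2\CCCCCC2=O)cc1` has methyl in place of fluoro on an aromatic carbon and still awaits measurement. Within the data shown here, no measured pair of compounds shows what this swap does, so no change beyond the scatter is expected. The expected step of a 1.2-fold lower number from compound 2 to compound 3 (0.07 log units; within the scatter) stays within that scatter. Compound 3 is estimated at 170000 nM with a likely range from 70000 nM to 400000 nM in this assay once tested.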

Compound 3, half-maximal inhibitory concentration: > 500000 nM
Compound 3: only a limit was reported (the forecaster's own chance of this, stated with the estimate: 10%); middle value at least 2.9-fold (0.46 log units) away from the limit.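

The position on the aromatic ring para to a group of 9 heavy atoms turns out to matter. In this assay, among these compounds, methyl in place of fluoro gives an at least 2.5-fold higher number from compound 2 to compound 3 (0.40 log units; beyond the scatter), the first readable change at this position, so exchanging one heavy atom here is enough to weaken inhibition. As far as these compounds go, the true size of the step stays open, as the reading for compound 3 is a limit of the assay and not a number: the limit of > 500000 nM in this assay, at which 1 of the 3 values shown sits.

From the compounds shown here alone, how an amine or a carboxylic acid would fare at this position remains open.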